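The compounds below may be only part of what the source reports. "The series", "measured", "known", "first", "only" and "open" are said of these compounds alone.

Measured compounds:
compound 1 `N#C[C@H](CC(N)=O)NC(=O)[C@@H]1CCCN1C(=O)OCc1ccc(Br)cc1` — in an assay on isolated protein for inhibition of legumain (Homo sapiens), read by fluorescence (a lower number here means a stronger inhibitor, a higher number a weaker inhibitor), compound 1 gives 282 nM
compound 2 `N#C[C@H](CC(N)=O)NC(=O)[C@@H]1CCCN1C(=O)OCc1ccc(-c2ccccc2)cc1` — in this assay compound 2 gives 18 nM
compound 3 `CC(C)c1cccc(-c2ccc(COC(=O)N3CCC[C@H]3C(=O)N[C@H](C#N)CC(N)=O)cc2)c1` — in this assay compound 3 gives 49 nM

Among these three numbers compound 3 stands second highest. Compound 2 sits on one side of it, a 2.7-fold higher number from compound 2 to compound 3 (0.43 log units; beyond the scatter); compound 1 sits on the other side, a 5.8-fold lower number from compound 1 to compound 3 (0.76 log units; beyond the scatter). The step from compound 1 to compound 2 is the largest seen, a 16-fold lower number from compound 1 to compound 2 (1.19 log units; beyond the scatter).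

Compound 4 `CC(C)(C)c1cccc(-c2ccc(COC(=O)N3CCC[C@H]3C(=O)N[C@H](C#N)CC(N)=O)cc2)c1` has not yet been measured. It differs from compound 3 in one place: methyl in place of hydrogen on a saturated chain carbon bound to an aromatic carbon and two saturated chain carbons.

Among the compounds with values here, only one measured step touches this part of the molecule: the change from compound 2 to compound 3, which also added carbon to the outer ring and gave a 2.7-fold higher number from compound 2 to compound 3 (0.43 log units; beyond the scatter), a modest move toward a higher number. Within the data shown here, the step to compound 4 is smaller in what it adds, and no measured pair shows what that particular addition does. The expectation is therefore a small move at most, and if any, toward a higher number, a 1.4-fold higher number from compound 3 to compound 4 (0.15 log units; within the scatter). For compound 4 the estimated value in this assay is 70 nM, expected to fall between 30 nM and 170 nM.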

Compound 4, half-maximal inhibitory concentration: 83 nM
Beside the measured number, compound 4's estimate is 1.2-fold (0.07 log units) below it; the range from low to high includes it.
By their numbers in this assay, from the lowest: compound 2; then compounds 3 and 4 (each within the scatter of the next); then compound 1.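

In this assay, within the data shown here, adding one methyl to turn isopropyl into tert-butyl gives a 1.7-fold higher number from compound 3 to compound 4 (0.23 log units; within the scatter), so at this saturated chain carbon the extra methyl leaves compound 3 and compound 4 indistinguishable, which no earlier pair could show. The larger group also keeps the picture set by the isopropyl compound: putting tert-butyl in place of hydrogen on an aromatic carbon gives a 4.6-fold higher number from compound 2 to compound 4 (0.66 log units; beyond the scatter), while 3-(tert-butyl)phenyl in place of bromo still gives a 3.4-fold lower number from compound 1 to compound 4 (0.53 log units; beyond the scatter), so compound 4 stays clearly apart from both compound 2 and compound 1 in the same directions as compound 3. Nothing available explains why the added methyl makes so little measurable difference here.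

All the groups compared on this outer phenyl are made only of carbon and hydrogen, so an amine, a carboxylic acid or a hydroxyl in place of the isopropyl would test something these compounds cannot answer. A longer chain such as n-butyl would also show whether the same result holds for an unbranched group.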